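The source may hold more compounds than are shown below. What is called first, only, known or untested is meant among the compounds shown, and "the series" means these compounds.

Three measured compounds share one core: compound 1 `CC1(c2ccc(NC(c3ccncc3)c3nnnn3C(C)(C)C)cc2)NC(=O)c2ccccc2N1`, compound 2 `CC1(c2ccc(NC(c3ccc(Cl)cc3)c3nnnn3C(C)(C)C)cc2)NC(=O)c2ccccc2N1` and compound 3 `COc1cc(C(Nc2ccc(C3(C)NC(=O)c4ccccc4N3)cc2)c2nnnn2C(C)(C)C)cc(OC)c1OC`. In an ADME assay on Vero cells (Chlorocebus sabaeus) for cytotoxicity, read by MTT assay, with a stated time of 72 h (on this read-out higher numbers stand for lower toxicity in this test and lower numbers for higher toxicity in this test), compound 1 gives "not determined" (no result reported). In this assay compound 3 also gives "not determined" (no result reported), so compound 3 stands without any number of its own in this test. Compound 2 is the only one of the three with a reported result, and that result is a limit of the assay rather than a number: in this assay compound 2 gives > 400000 nM. Everything known here therefore rests on (the limit of > 400000 nM in this assay, at which 1 of the 3 values shown sits). Going by the values given here, no step between two measured compounds can be drawn from these data.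

The unmeasured compound 4 `CC1(c2ccc(NC(c3ccc(Br)cc3)c3nnnn3C(C)(C)C)cc2)NC(=O)c2ccccc2N1` arises from compound 3 through (4-bromophenyl in place of 3,4,5-trimethoxyphenyl on a saturated chain carbon bound to an aromatic carbon and a nitrogen on an aromatic ring). Among the compounds with values here, with no measured step to lean on, the size of the change in this assay cannot be read from the data, and nothing in them suggests a movement beyond the usual scatter in either direction. Because the single available result is the limit of > 400000 nM in this assay, at which 1 of the 3 values shown sits, compound 4 is expected to give about 400000 nM in this assay, with an estimated range from 100000 nM to 1000000 nM.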

Compound 4, half-maximal cytotoxic concentration: > 400000 nM
Compound 4 was reported as a limit (the forecaster's own chance of this, stated with the estimate: 70%); the middle value lies on the limit itself.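

Compound 2 and compound 4 are both reported as limits rather than numbers, so no step between these two compounds can be read: the limit of > 400000 nM in this assay, at which 2 of the 4 values shown sit.

The compounds shown leave open whether any change on the shared core moves the result in this assay at all.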